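Replacing the cyclopropylamino side chain of compound 2

The compounds below may be only part of what the source reports. "The series", "measured", "known", "first", "only" and "open" are said of these compounds alone.

In an ADME assay on HEp-2 cells (Homo sapiens) for cytotoxicity (on this read-out lower numbers stand for higher toxicity in this test and higher numbers for lower toxicity in this test), compound 2 `CC(C)CCn1c(Cn2c(=O)n(C(C)C)c3ccccc32)nc2cc(CNC3CC3)ccc21` gives 17200 nM as the highest of three measured numbers. Compound 1 `CC(C)CCn1c(Cn2c(=O)n(C(C)C)c3ccccc32)nc2c(CN)cccc21` gives 7000 nM and compound 3 `CC(C)CCn1c(Cn2c(=O)n(C(C)C)c3ccccc32)nc2cc(CN(C)C)ccc21` gives 5650 nM in this assay as well, both lower than compound 2.

Compound 4 `CC(C)CCn1c(Cn2c(=O)n(C(C)C)c3ccccc32)nc2cc(C(C)(C)N)ccc21` has not been measured yet. It carries 1-amino-1-methylethyl in place of (cyclopropylamino)methyl on an aromatic carbon, and the full count of that change is 1-amino-1-methylethyl in place of (cyclopropylamino)methyl on an aromatic carbon for anyone comparing the two groups.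

Among the measured compounds shown here, only one measured step also removes the cyclopropylamino group. That step is a 3.0-fold lower number from compound 2 to compound 3 (0.48 log units; beyond the scatter) and it points downward. It is a single example with a different incoming group, so it offers a direction and a rough size, not a rule.

In this assay the expected move is a 2.2-fold lower number from compound 2 to compound 4 (0.33 log units; beyond the scatter) and so a modest drop is estimated. The estimate for compound 4 is 8000 nM within an expected range from 3500 nM to 17000 nM for this measurement.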

Compound 4, half-maximal cytotoxic concentration: 3270 nM
Compound 4: middle estimate off by 2.4-fold (0.39 log units), on the high side, outside the stated range (below it).
By their numbers in this assay, from the lowest: compounds 4, 3 and 1 (each within the scatter of the next, the first and the last beyond it); then compound 2.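

In this assay, the swap to 1-amino-1-methylethyl gives a 5.3-fold lower number from compound 2 to compound 4 (0.72 log units; beyond the scatter). Among the compounds shown here, compound 3 is therefore no longer the only example: two different groups in place of (cyclopropylamino)methyl on this aromatic carbon both give a lower number than compound 2. The further step shows a 1.7-fold lower number from compound 3 to compound 4 (0.24 log units; within the scatter), so this test does not separate (dimethylamino)methyl from 1-amino-1-methylethyl, and no measurement here explains the drops.

The compounds shown leave open whether the high number of compound 2 goes with its three-membered ring, which (cyclobutylamino)methyl or (isopropylamino)methyl on the same aromatic carbon could help to answer. They also leave open whether an amine is needed on this side chain at all, which a hydroxymethyl group could probe.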